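A few compounds are considered here, and "the series" means these few. Any claim that something is new, unique, unknown or untested is made for them only; others in the source may bear on it.

For the measured compounds named here, compound 2 `COc1cccc(Cn2cnc3sc(-c4ccnc(Cl)c4)cc3c2=O)c1` gives 501 nM in an assay on isolated protein for inhibition of Rho-associated protein kinase 2 (Homo sapiens), read by radiometric assay and 33P incorporation, with a stated time of 40 min, in the presence of a further agent that is not named here (a higher number here means a weaker inhibitor, a lower number a stronger inhibitor), the highest of the two numbers so far; compound 1 `COc1cccc(Cn2cnc3sc(-c4ccnc(F)c4)cc3c2=O)c1` gives 83 nM. Going by the values given here, the one measured step, a 6.0-fold higher number from compound 1 to compound 2 (0.78 log units; beyond the scatter), shows a modest weakening when the halogen grows from fluoro to chloro. Compound 3 `COc1cccc(Cn2cnc3sc(-c4ccnc(OC)c4)cc3c2=O)c1` carries methoxy in place of chloro on an aromatic carbon. Among the compounds with values here, no measured step swaps chloro for methoxy, so the direction of this change is open. For compound 3 a number close to that of compound 2 is therefore expected, a 1.0-fold lower number from compound 2 to compound 3 (0.00 log units; within the scatter), within the scatter. The estimate for compound 3 is 500 nM, with a range from 150 nM to 1700 nM.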

Compound 3, half-maximal inhibitory concentration: 6920 nM
For compound 3 the middle estimate is 14-fold (1.14 log units) below the measured one, and the stated range ends below it.
By their numbers in this assay, from the lowest: compound 1; then compound 2; then compound 3.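

On the six-membered aromatic ring with 1 nitrogen, the position next to the ring nitrogen is sensitive to more than the choice of halogen: methoxy brings a 14-fold higher number from compound 2 to compound 3 (1.14 log units; beyond the scatter) and, measured against fluoro, an 83-fold higher number from compound 1 to compound 3 (1.92 log units; beyond the scatter) in this assay for this series. Across these three compounds the order runs fluoro, then chloro, then methoxy, and the methoxy change is the larger one. Nothing measured here explains this order. Still open, going by these compounds, is how a plain hydrogen, a methyl group or an amine would behave at this position, and whether any group can beat fluoro there.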